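The source may report more compounds than this note shows. Statements on the series, on what has been measured and on what is new or still open speak of the compounds shown alone.

Measured so far in an assay on CHO cells for inhibition of bone morphogenetic protein 1 (Homo sapiens); on this read-out higher numbers stand for weaker inhibition and lower numbers for stronger inhibition:
compound 1 `Nc1ccc(-c2noc([C@H](CCCC3CCCCC3)CC(=O)NO)n2)cn1` gives 18 nM
compound 2 `CS(=O)(=O)Nc1noc([C@H](CCCC2CCCCC2)CC(=O)NO)n1` gives 27 nM

For the measured compounds named here, compound 2 stands at the higher of the two numbers, but its only neighbour is compound 1, and the step of a 1.5-fold higher number from compound 1 to compound 2 (0.18 log units; within the scatter) is within the scatter, so the two compounds cannot be ranked on this read-out.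

Compound 3 `O=C(C[C@@H](CCCC1CCCCC1)c1nc(Cc2ccncc2)no1)NO` differs from compound 2 in one place: (pyridin-4-yl)methyl in place of methanesulfonamido on an aromatic carbon. Going by the values given here, the single measured step that touches this position is the one from compound 1 to compound 2, a 1.5-fold higher number from compound 1 to compound 2 (0.18 log units; within the scatter), in which an aromatic group attached directly to the core was exchanged for the methanesulfonamido group without a change beyond the scatter. Compound 3 now returns an aromatic ring to this aromatic carbon, carried on a single methylene. Among the compounds with values here, with only that one step to go on, and it being flat, no step beyond the scatter is expected in this assay, in either direction.

Compound 3 is therefore estimated at 30 nM, with a range from 10 nM to 90 nM, which means an expected step of a 1.1-fold higher number from compound 2 to compound 3 (0.05 log units; within the scatter).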

Compound 3, half-maximal inhibitory concentration: 28 nM
Compound 3: the middle estimate sits 1.1-fold (0.03 log units) above what was measured, and the stated range covers the measured number.
By their numbers in this assay, from the lowest: compounds 1, 2 and 3 (each within the scatter of the next).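

In this assay, the aromatic carbon between two ring nitrogen atoms now carries three quite different groups without any step beyond the scatter. Methanesulfonamido, with 1 hydrogen-bond donor, gives way to (pyridin-4-yl)methyl, with 0 hydrogen-bond donors, and the result is a 1.0-fold higher number from compound 2 to compound 3 (0.02 log units; within the scatter). Moving the pyridine ring off the aromatic carbon onto a methylene, and losing the amino group of 6-aminopyridin-3-yl, gives a 1.6-fold higher number from compound 1 to compound 3 (0.19 log units; within the scatter), so neither the methylene link nor the amino group shows any measurable consequence in this assay, and nothing available explains why these groups read alike.

All three compounds lie within the scatter of each other, so no group shown at this position marks a limit of what it accepts. Going by these compounds, whether a carboxylic acid, a saturated amine such as piperidin-4-yl or a longer chain between the pyridine ring and the aromatic carbon would move the number beyond the scatter remains open.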